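Extending the hydroxymethyl arm of compound 1 by one carbon

A few compounds are considered here, and "the series" means these few. Any claim that something is new, unique, unknown or untested is made for them only; others in the source may bear on it.

Measured compounds:
compound 1, `O=S1(=O)Cc2nc(-c3cc(F)c(Cl)cc3F)nc(N3CCC(CO)CC3)c2C1`: 16000 nM
compound 2, `NC(=O)C1CCN(c2nc(-c3cc(F)c(Cl)cc3F)nc3c2CS(=O)(=O)C3)CC1`: 40000 nM

Compound 1 was studied in a physicochemical assay for solubility, with a stated time of 20 h, at pH 6.8; a lower number here means a less soluble compound, a higher number a more soluble compound. Among the compounds measured so far, compound 1 has the lowest solubility, and the only neighbour is compound 2, which sits a 2.5-fold higher number from compound 1 to compound 2 (0.40 log units; beyond the scatter) away; that step swapped one substituent on the saturated ring for another.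

Compound 3, `O=S1(=O)Cc2nc(-c3cc(F)c(Cl)cc3F)nc(N3CCC(CCO)CC3)c2C1`, differs from compound 1 in a smaller way: hydroxymethyl in place of hydroxy on a saturated chain carbon bound to a saturated ring carbon. Within the data shown here, no measured pair shows this exact change, so the only guide is that the one recorded alteration at this part of the molecule, from compound 1 to compound 2, moved the solubility by a modest amount. Inserting one carbon while keeping the same donor and acceptor is a smaller perturbation than replacing the group, so the change in this assay is expected to be small, without a clear direction.

Compound 3 is therefore estimated at 16000 nM, with a likely range from 7000 nM to 36000 nM, which corresponds to an expected step of no change at the digits printed from compound 1 to compound 3 (within the scatter).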

Compound 3, solubility: 23000 nM
Beside the measured number, compound 3's estimate is 1.4-fold (0.16 log units) below it; low and high end bracket the measured number.
By their numbers in this assay, from the lowest: compounds 1, 3 and 2 (each within the scatter of the next, the first and the last beyond it).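

In this assay, lengthening the arm from hydroxymethyl to 2-hydroxyethyl gives a 1.4-fold higher number from compound 1 to compound 3 (0.16 log units; within the scatter), so this added chain carbon produces a gap no larger than repeated measurements of the same compound could show. Comparing 2-hydroxyethyl with carbamoyl on a saturated ring carbon gives a 1.7-fold lower number from compound 2 to compound 3 (0.24 log units; within the scatter), which also cannot be told apart from scatter. Compound 3 therefore cannot be separated from either neighbour, even though the two neighbours themselves differ, with a 2.5-fold higher number from compound 1 to compound 2 (0.40 log units; beyond the scatter), so these three compounds give no clear ranking of the 2-hydroxyethyl arm against the other two groups.

As far as these compounds go, it remains open whether a longer chain, such as 3-hydroxypropyl, or an arm ending in an amine or a carboxylic acid, would stay this close to compound 1 or move clearly beyond the scatter. The data shown also contain no measurement that could explain why these three numbers fall where they do.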